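The source may hold more compounds than are shown below. What is called first, only, known or untested is meant among the compounds shown, and "the series" means these compounds.

Compound 1 `Cc1cccc(-c2cc(O)c3ccc(C)nc3n2)c1` and compound 3 `Cc1cccc(-c2cc(O)c3c(C)cc(C)nc3n2)c1` differ in one place: hydrogen in place of methyl on an aromatic carbon. In a functional assay on CAKI-1 cells (Homo sapiens) for antiproliferative activity (on this read-out higher numbers stand for weaker inhibition of growth and lower numbers for stronger inhibition of growth), compound 3 gives 56200 nM, whereas compound 1 gives 427 nM, so the step of a 130-fold lower number from compound 3 to compound 1 (2.12 log units; beyond the scatter) is large. Compound 2 `Cc1cc(C)c2c(O)cc(-c3cccc4ccccc34)nc2n1` gives 9550 nM in this assay; how its core differs from that of compound 3 is not broken down here. Compound 4 `Cc1ccc2c(O)cc(-c3cccc4ccccc34)nc2n1` is not yet measured, and it stands to compound 2 as compound 1 stands to compound 3, the same change: hydrogen in place of methyl on an aromatic carbon. Resting on the step from compound 3 to compound 1 a 130-fold lower number from compound 3 to compound 1 (2.12 log units; beyond the scatter), the author expects a similarly large step a 64-fold lower number from compound 2 to compound 4 (1.80 log units; beyond the scatter) in this assay, tempered: a single earlier instance carries the whole weight. Compound 4 is therefore estimated at 150 nM, between 30 nM and 800 nM.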

Compound 4, concentration for 50% growth inhibition: 6030 nM
Compound 4: the middle estimate sits 40-fold (1.60 log units) below what was measured; measured number above the stated range.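

The replacement of methyl by hydrogen on the aromatic carbon did not repeat its earlier effect in this assay, where the new step is a 1.6-fold lower number from compound 2 to compound 4 (0.20 log units; within the scatter). The size of the step therefore cannot simply be carried from one core to another in this series, as the two instances clearly disagree: the same change on two cores in this assay, a 130-fold lower number (2.12 log units; beyond the scatter) from compound 3 to compound 1 and a 1.6-fold lower number (0.20 log units; within the scatter) from compound 2 to compound 4, 83-fold (1.92 log units) apart, beyond the scatter of two such steps. With only two instances, this shows that the outcome of the change differs between these two cores, but it does not show which structural difference between them decides the outcome or what a third core would do.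

The compounds shown leave open how an amine, a carboxylic acid or a longer chain on that aromatic carbon would read in this assay. They also leave open whether either core would respond to such groups as it did to methyl and hydrogen.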